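The compounds below may be only part of what the source reports. "The series", "measured", "known", "first", "only" and "open" are said of these compounds alone.

Measured in an assay on isolated protein for inhibition of Nitric oxide synthase, inducible (Homo sapiens), read by scintillation counting, with a stated time of 30 min, tested at 50 uM; a higher number here means more inhibition at the concentration tested (going by the name of the read-out), a lower number less inhibition:
compound 1 `CC(=O)N1N=C(c2ccccc2N)SC1(C)C` gives 22.9%
compound 2 `CCC(=O)N1N=C(c2ccccc2N)SC1(C)C` gives 19.2%
compound 3 `CCCCC(=O)N1N=C(c2ccccc2N)SC1(C)C` gives 39.1%

Compound 3 holds the highest number of the three. The two steps leading up to it are a number 16.2 percentage points higher from compound 1 to compound 3 (beyond the scatter) and a number 19.9 percentage points higher from compound 2 to compound 3 (beyond the scatter), both beyond the scatter. Between compound 1 and compound 2 the step is a number 3.7 percentage points lower from compound 1 to compound 2 (within the scatter), within the scatter, so those two are not ordered against each other.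

Compound 4 `CC1(C)SC(c2ccccc2N)=NN1C(=O)C1CCC1` differs from compound 3 in one place: cyclobutyl in place of butyl on a carbonyl carbon. The measured steps all concern lengthening of the chain on the carbonyl carbon; none exchanges an open chain for a ring of the same count, so none bears directly on this change. The steps to compound 3 show that the group on the carbonyl carbon can move the read-out, but they give no direction for a swap that keeps the heavy atom count. The expected step in this assay is therefore none beyond the scatter, a number 2.1 percentage points lower from compound 3 to compound 4 (within the scatter). Compound 4 is estimated at 37%, with a range of 22% to 52%.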

Compound 4, a percentage reported as inhibition, at one concentration (the size of the read-out at that concentration, not a potency): 46.9%
Estimate against measurement, compound 4: 9.9 percentage points below; low and high end bracket the measured number.
By their numbers in this assay, from the lowest: compounds 2 and 1 (each within the scatter of the next); then compounds 3 and 4 (each within the scatter of the next).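

In this assay, replacing butyl with cyclobutyl on the carbonyl carbon gives a step within the scatter (a number 7.8 percentage points higher from compound 3 to compound 4 (within the scatter)), so at this position the open chain and the four-membered ring of the same heavy atom count are not told apart. Cyclobutyl also stands beyond the scatter from the two shorter groups (a number 27.7 percentage points higher from compound 2 to compound 4 (beyond the scatter); a number 24 percentage points higher from compound 1 to compound 4 (beyond the scatter)), which places compound 4 with compound 3 in the upper pair of the series and shows that the higher read-out is not confined to an open chain. No evidence is available on what lies behind these steps.

As far as these compounds go, whether cyclopropyl, cyclohexyl or phenyl on the same carbonyl carbon would stay with this upper pair remains open. From the compounds shown here alone, these single-concentration percentages are not potencies, so how compound 3 and compound 4 compare in potency also remains open.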